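Replacing the Aryl Group of Compound 2

This account rests on a few compounds, and the source may have more. Where it says the series, first, only, none or still open, it means among the compounds named here.

- compound 1 `CCC1=C(O)c2c(oc(-c3ccc(C)cc3)cc2=O)C(CC)(CC)C1=O`: 0.08 uM
- compound 2 `CCC1=C(O)c2c(oc(-c3ccc(OC)c(Cl)c3)cc2=O)C(CC)(CC)C1=O`: 1.37 uM

In a functional assay on KBVIN cells (Homo sapiens) for antiproliferative activity, read by sulforhodamine B assay, with a stated time of 3 days (on this read-out higher numbers stand for an effect only at larger amounts of compound and lower numbers for an effect already at smaller amounts), compound 2 has the higher number of the two at 1.37 uM, so it needs the larger amount for its effect. The unmeasured compound 3 `CCC1=C(O)c2c(oc(-c3cc(C)ccc3F)cc2=O)C(CC)(CC)C1=O` changes the same place on the shared core, with 2-fluoro-5-methylphenyl in place of 3-chloro-4-methoxyphenyl (2-fluoro-5-methylphenyl in place of 3-chloro-4-methoxyphenyl on an aromatic carbon). For the measured compounds named here, only one measured step bears on this: a 17-fold higher number from compound 1 to compound 2 (1.23 log units; beyond the scatter), a large step beyond the scatter. Going by the values given here, the entering group has a methyl and a phenyl in its name, as does the 4-methylphenyl of compound 1, but no measured compound carries this exact group. A move back towards compound 1 in this assay is therefore expected, though only part of the way. The expected change is a 3.9-fold lower number from compound 2 to compound 3 (0.59 log units; beyond the scatter). For compound 3 the estimated value is 0.35 uM, with an expected range of 0.07 uM to 1.7 uM.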

Compound 3, concentration for half-maximal effect: 3.24 uM
For compound 3 the middle estimate is 9.3-fold (0.97 log units) below the measured one; the measured number lies above the stated range.
By their numbers in this assay, from the lowest: compound 1; then compound 2; then compound 3.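

In this assay, the change to 2-fluoro-5-methylphenyl gives a 2.4-fold higher number from compound 2 to compound 3 (0.37 log units; beyond the scatter), so the number moves further from compound 1 rather than back towards it. The other step, a 41-fold higher number from compound 1 to compound 3 (1.61 log units; beyond the scatter), shows that a methyl on the phenyl ring does not by itself keep the low number of compound 1, and that both groups carrying a halogen end up higher than the 4-methylphenyl group. Nothing available here explains these differences.

Compared with compound 1, compound 3 adds a fluorine and also has its methyl at a different place on the phenyl ring, so the share of each in the step stays open. Going by these compounds, it also remains open whether a simpler group, such as 4-fluorophenyl or 4-aminophenyl, would stay close to compound 1.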